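Chalcone series: fluoro for ethyl on the aryl ring

This account rests on a few compounds, and the source may have more. Where it says the series, first, only, none or still open, it means among the compounds named here.

Compound 3 `CCc1ccc(/C=C/C(=O)c2ccc(-n3ccnc3)cc2)cc1` gives 320 nM in an assay on isolated protein for inhibition of Amine oxidase [flavin-containing] B (Homo sapiens) (on this read-out higher numbers stand for weaker inhibition and lower numbers for stronger inhibition), the higher of the two numbers reported, and its nearest neighbour is compound 1 `CCOc1ccc(C(=O)/C=C/c2ccc(F)cc2)cc1`, which gives 53 nM in this assay, a gap that lies beyond the scatter. Compound 2 `O=C(/C=C/c1cccc(F)c1)c1ccc(-n2ccnc2)cc1` reaches only the limit of this assay, > 10000 nM, a limit and not a number. Compound 4 `O=C(/C=C/c1ccc(F)cc1)c1ccc(-n2ccnc2)cc1` is not yet measured; it differs from compound 3 by fluoro in place of ethyl on an aromatic carbon, on an aromatic carbon para to a large group. Within the data shown here, with no step between measured compounds available, a modest weakening is expected in this assay, so that a 2.5-fold higher number from compound 3 to compound 4 (0.40 log units; beyond the scatter) goes upward. Compound 4 is estimated at 800 nM, in the range 150 nM to 5000 nM.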

Compound 4, half-maximal inhibitory concentration: > 10000 nM
Compound 4 gave a limit, no number (the forecaster's own chance of this, stated with the estimate: 20%); middle value at least 12-fold (1.09 log units) from the limit.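

Fluoro in place of ethyl on this aromatic carbon, para to a large group, is far from neutral in this assay: an at least 31-fold higher number from compound 3 to compound 4 (1.49 log units; beyond the scatter), with compound 4 at a limit and not a number. With the fluoro kept, 1H-imidazol-1-yl in place of ethoxy also costs heavily: an at least 180-fold higher number from compound 1 to compound 4 (2.27 log units; beyond the scatter). The step between the two fluoro isomers, compound 2 and compound 4, cannot be read, since both sit at a limit: the limit of > 10000 nM in this assay, at which 2 of the 4 values shown sit.

Open, going by these compounds, is whether methyl, chloro, methoxy or a longer chain on this carbon keeps a measurable number with 1H-imidazol-1-yl in place.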